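Removing the methoxy from an indole vinyl sulfone

The source may report more compounds than this note shows. Statements on the series, on what has been measured and on what is new or still open speak of the compounds shown alone.

Measured compounds:
compound 1, `COc1ccc(-c2[nH]c3ccccc3c2/C=C(\C#N)S(=O)(=O)c2ccccc2)cc1`: 1500 nM
compound 2, `CCOC(=O)C(=Cc1c(-c2ccccc2)[nH]c2ccccc12)C(=O)OCC`: 12700 nM

In a functional assay on NCI-H322M cells (Homo sapiens) for inhibition, read by sulforhodamine B assay, with a stated time of 48 h (on this read-out lower numbers stand for stronger inhibition of growth and higher numbers for weaker inhibition of growth), compound 1 gives 1500 nM, the lowest of the two numbers. Compound 2 gives 12700 nM, a higher number that lies beyond the usual scatter. For the measured compounds named here, no step between measured compounds that differ in one place exists, so the change studied here has no direct precedent. Compound 3, `N#C/C(=C\c1c(-c2ccccc2)[nH]c2ccccc12)S(=O)(=O)c1ccccc1`, differs from compound 1 by hydrogen in place of methoxy on an aromatic carbon, which reads 4-methoxyphenyl to phenyl. A loss of growth inhibition somewhat beyond the scatter is expected, as the step of a 2.3-fold higher number from compound 1 to compound 3 (0.37 log units; beyond the scatter). Compound 3 is estimated at 3500 nM, within 900 nM to 14000 nM.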

Compound 3, concentration for 50% growth inhibition: 9200 nM
For compound 3 the middle estimate is 2.6-fold (0.42 log units) below the measured one; the measured number falls inside the stated range.
By their numbers in this assay, from the lowest: compound 1; then compounds 3 and 2 (each within the scatter of the next).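

Replacing the methoxy with hydrogen gives [ a 6.1-fold higher number from compound 1 to compound 3 (0.79 log units; beyond the scatter) ] in this assay, so growth inhibition weakens when this group is lost. This first comparison of compounds that differ in one place shows that, on this core, the substituent on the aromatic ring affects the result, and that 4-methoxyphenyl outperforms phenyl. No independent measurement here explains the loss. From the compounds shown here alone, whether this gain is particular to methoxy remains open, since a single pair cannot separate it from other groups. An ethoxy, a hydroxyl or an amine at the same place would test this.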